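The source may report more compounds than this note shows. Statements on the series, on what has been measured and on what is new or still open speak of the compounds shown alone.

Measured compounds:
- compound 1 `C/C(=N\NC(N)=S)c1ccc(C)cc1` gives 840 nM in a functional assay on B16 cells (Mus musculus) for inhibition, with a stated time of 3 days; on this read-out lower numbers stand for stronger inhibition and higher numbers for weaker inhibition
- compound 2 `CC/C(=N\NC(N)=S)c1ccc(C)cc1` gives 2600 nM in this assay
- compound 3 `CC/C(=N\N=C(\N)S)c1ccc(OC)cc1` gives 4000 nM in this assay

Among these three numbers compound 2 stands second highest. Within the data shown here, its nearest neighbour is compound 3, whose value lies within the scatter of it, so no order between compound 2 and compound 3 can be read from the data; the only step beyond the scatter runs a 3.1-fold higher number from compound 1 to compound 2 (0.49 log units; beyond the scatter), a modest rise in the number.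

Compound 4 `CC/C(=N\NC(=S)NC)c1ccc(C)cc1` has not been measured in this assay. It differs from compound 2 by methyl in place of hydrogen on an amide-type nitrogen, that is, amino becomes methylamino at the thiourea end of the molecule. Among the measured compounds shown here, no measured pair shows this change: the one step known, a 3.1-fold higher number from compound 1 to compound 2 (0.49 log units; beyond the scatter), concerns a methyl added on a saturated chain carbon bound to a carbon with a double bond to nitrogen, a different place, and compound 3 differs from compound 2 in two places at once, so its value only shows that a related compound sits near compound 2. For the measured compounds named here, with no direct precedent, the step of a 1.2-fold higher number from compound 2 to compound 4 (0.06 log units; within the scatter) is expected to stay within the scatter, with a broad uncertainty either way. Compound 4 is therefore estimated at 3000 nM, within a range from 1000 nM to 9000 nM.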

Compound 4, half-maximal inhibitory concentration: 2000 nM
Compound 4: middle estimate off by 1.5-fold (0.18 log units), on the high side, within the range that was stated.
By their numbers in this assay, from the lowest: compound 1; then compounds 4, 2 and 3 (each within the scatter of the next).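

In this assay, among these compounds, the first change at the thiourea end of the molecule, methyl in place of hydrogen on an amide-type nitrogen, gives a 1.3-fold lower number from compound 2 to compound 4 (0.11 log units; within the scatter), so amino to methylamino produces no step that can be read in this pair. Among the compounds shown here, the earlier compounds could not show this: their only single-place step, a 3.1-fold higher number from compound 1 to compound 2 (0.49 log units; beyond the scatter), concerns a methyl on a saturated chain carbon, and that step lies beyond the scatter, whereas the new one, at a different place, does not. Within these two pairs, then, adding a methyl has a readable result only on the chain, and nothing available explains this difference between the two places.

The compounds shown leave open whether this amide-type nitrogen would accept more than a methyl, such as an ethyl group, a longer chain, a phenyl ring or a chain ending in a carboxylic acid. They also leave open whether amino to methylamino would give a similar result on the core of compound 1, or on the core of compound 3, which differs from compound 2 in two places.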